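Bromine in Place of Methyl on the Aryl Ring

The source may report more compounds than this note shows. Statements on the series, on what has been measured and on what is new or still open speak of the compounds shown alone.

Measured compounds:
compound 1 `COc1ccccc1Oc1c(N)nc(-c2cccc(C)c2)nc1Cl` — 13100 nM
compound 2 `COc1ccccc1Oc1c(N)nc(-c2ccc(F)cc2)nc1Cl` — 2990 nM

Two compounds share a core and differ only in the aromatic ring attached to it. In a functional assay on B16 cells (Mus musculus) for cytotoxicity, read by CCK-8 assay, with a stated time of 24 h (a higher number here means a weaker inhibitor, a lower number a stronger inhibitor), compound 1 gives 13100 nM, the highest of the two numbers. Compound 2 gives 2990 nM, and the step of a 4.4-fold lower number from compound 1 to compound 2 (0.64 log units; beyond the scatter) shows that exchanging the aromatic ring's substituent and its position lowers the number beyond the scatter.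

Compound 3 `COc1ccccc1Oc1c(N)nc(-c2cccc(Br)c2)nc1Cl` is not yet measured. Relative to compound 1 it differs as follows: bromo in place of methyl on an aromatic carbon. The bromine sits where the methyl stood, so the position is kept and only the atom type changes.

Among the compounds with values here, only the step from compound 1 to compound 2 bears on this, and it is an imperfect guide: it moves a halogen to a different position rather than placing one where the methyl was. That step was modest, and a halogen in place of methyl is expected to give a smaller shift in this assay, most likely toward a lower number. Compound 3 is therefore expected to reach 7000 nM, a step of a 1.9-fold lower number from compound 1 to compound 3 (0.27 log units; within the scatter), within a range of 2500 nM to 20000 nM.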

Compound 3, half-maximal inhibitory concentration: 24600 nM
Compound 3: the middle estimate sits 3.5-fold (0.55 log units) below what was measured; measured number outside the range, above it.
By their numbers in this assay, from the lowest: compound 2; then compounds 1 and 3 (each within the scatter of the next).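

In this assay, bromo in place of methyl on the same aromatic carbon gives a 1.9-fold higher number from compound 1 to compound 3 (0.27 log units; within the scatter), so at this position, meta to a large group, the two groups cannot be told apart in this assay. The other comparison gives an 8.2-fold higher number from compound 2 to compound 3 (0.92 log units; beyond the scatter), which shows that having a halogen on the aromatic ring does not by itself bring the number down to that of compound 2. No independent measurement is available to explain either result.

The step between compound 2 and compound 3 changes both the halogen and its place on the ring, and because fluoro and bromo never stand on the same carbon in these compounds, the two changes cannot be separated. As far as these compounds go, it also remains open how this position would respond to a group of a different kind, such as an amine or a carboxylic acid, since methyl and bromo are the only two substituents compared on this carbon.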